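Notes on compound 3: chloro in place of fluoro

The compounds below may be only part of what the source reports. "The series", "measured", "known", "first", "only" and "open" are said of these compounds alone.

Measured so far:
Compound 1, `CCN(CC)c1nc(Nc2cccc(C(=O)O)c2)nc(OCC(F)(F)C(F)F)n1`: 500 nM in an assay on cells for activation of Cystic fibrosis transmembrane conductance regulator (Homo sapiens), read by fluorescence, with stated times of 10 min and 12 s; on this read-out higher numbers stand for an effect only at larger amounts of compound and lower numbers for an effect already at smaller amounts
Compound 2, `CCN(CC)c1nc(Nc2cccc(F)c2)nc(OCC(F)(F)C(F)F)n1`: 1600 nM in this assay

Compound 2 gives the highest number of the two measured. Among the compounds with values here, its nearest neighbour is compound 1, and the single one-place comparison in hand is a 3.2-fold higher number from compound 1 to compound 2 (0.51 log units; beyond the scatter), a modest change that lies beyond the scatter.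

Compound 3, `CCN(CC)c1nc(Nc2cccc(Cl)c2)nc(OCC(F)(F)C(F)F)n1`, is not yet measured. It differs from compound 2 by chloro in place of fluoro on an aromatic carbon. Within the data shown here, no measured step bears directly on this change: the only step available, a 3.2-fold higher number from compound 1 to compound 2 (0.51 log units; beyond the scatter), concerns carboxy against fluoro and says nothing about one halogen against another. The two measured compounds thus fix only the region around compound 2, and the exchange itself is expected to move the number little, quite possibly not beyond the scatter, with no direction favoured. For compound 3 the expected step is a 1.2-fold lower number from compound 2 to compound 3 (0.09 log units; within the scatter). Compound 3 is estimated at 1300 nM in this assay, with a range from 450 nM to 4000 nM.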

Compound 3, half-maximal effective concentration: 5400 nM
Compound 3: the middle estimate sits 4.2-fold (0.62 log units) below what was measured; the whole stated range lies below it.
By their numbers in this assay, from the lowest: compound 1; then compound 2; then compound 3.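

In this assay, the two halogens are not interchangeable at this place on the aromatic ring: the change shows a 3.4-fold higher number from compound 2 to compound 3 (0.53 log units; beyond the scatter), even though one heavy atom replaces one heavy atom and neither group brings hydrogen-bond donors or acceptors. The carboxy comparison now extends to a second halogen, with an 11-fold higher number from compound 1 to compound 3 (1.03 log units; beyond the scatter), so the three groups on this aromatic carbon give numbers rising from carboxy through fluoro to chloro, and every step among them lies beyond the scatter. Nothing in hand accounts for the difference between the two halogens.

Still open, from the compounds shown here alone, is how other groups on this carbon would rank against these three, among them bromo, methyl, an amine, a nitrile or an amide, and whether a plain hydrogen there would fall nearer the carboxy compound or the halogens. Also open, going by these compounds, is whether the same order of carboxy, fluoro and chloro would hold if the diethylamino group on the shared core gave way to a cyclic amine or a longer chain.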